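This account rests on a few compounds, and the source may have more. Where it says the series, first, only, none or still open, it means among the compounds named here.

Of the compounds shown here, three built on the shared core have been measured in a functional assay on the whole organism (strain Wistar albino) for inhibition, with Rattus norvegicus as the target, read by paw edema, with a stated time of 3 h, at a dose of 25 mg/kg by the oral route; on this read-out lower numbers stand for less inhibition and higher numbers for more inhibition at the one dose given (going by the name of the read-out). Compound 1 `CSc1nn(-c2ccccc2)c2nc(Nc3ccccc3)n(-c3ccccc3)c(=O)c12` gives 25.4%, compound 2 `O=c1c2c(Nc3ccc([N+](=O)[O-])cc3)nn(-c3ccccc3)c2nc(Nc2ccccc2)n1-c1ccccc1` gives 15.1%, and compound 3 `Cc1ccc(Nc2nn(-c3ccccc3)c3nc(Nc4ccccc4)n(-c4ccccc4)c(=O)c23)cc1` gives 32.9%. Compound 3 holds the highest of the three numbers; its nearest neighbour is compound 1, where the step of a number 7.5 percentage points higher from compound 1 to compound 3 (within the scatter) lies within the scatter, while the gap to compound 2, read as a number 17.8 percentage points higher from compound 2 to compound 3 (beyond the scatter), lies beyond it.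

Compound 4 `O=c1c2c(Nc3ccc(Cl)cc3)nn(-c3ccccc3)c2nc(Nc2ccccc2)n1-c1ccccc1` differs from compound 3 in a single place: chloro in place of methyl on an aromatic carbon. The step that bears most directly on this change is a number 17.8 percentage points higher from compound 2 to compound 3 (beyond the scatter), since it too swaps one group on the same ring, and the step of a number 10.3 percentage points lower from compound 1 to compound 2 (beyond the scatter) shows that the nitro-bearing compound sat lowest of the set. Chloro itself has no measured counterpart in these data, so its direction in this assay is open. The step of a number 4.9 percentage points lower from compound 3 to compound 4 (within the scatter) is expected to stay within the scatter. Compound 4 is estimated at 28%, with a range from 15% to 40%.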

Compound 4, a percentage reported as inhibition, in the whole organism at one dose (the size of the read-out at that dose, not a potency): 28.7%
Compound 4: middle estimate off by 0.7 percentage points, on the low side, and the stated range covers the measured number.
By their numbers in this assay, from the lowest: compound 2; then compounds 1, 4 and 3 (each within the scatter of the next).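

In this assay, for the compounds shown here, the swap of methyl for chloro gives a number 4.2 percentage points lower from compound 3 to compound 4 (within the scatter), so these two groups on the aromatic ring of the arylamino substituent cannot be told apart, and the replacement of nitro by chloro gives a number 13.6 percentage points higher from compound 2 to compound 4 (beyond the scatter), which makes nitro the one group of the three at this place that stands apart. The exchange of methylsulfanyl for (4-chlorophenyl)amino gives a number 3.3 percentage points higher from compound 1 to compound 4 (within the scatter), so among the three arylamino compounds only compound 2 separates from compound 1. No measurement at hand explains why nitro behaves differently at this place.

The compounds shown leave open how a methoxy group, a carboxylic acid or an amine would read at this place. They also leave open whether a plain phenylamino group, with only hydrogen there, would fall with compound 2 or with compound 3 and compound 4.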